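Changing the side chain in a level series

The source may report more compounds than this note shows. Statements on the series, on what has been measured and on what is new or still open speak of the compounds shown alone.

In a functional assay (plasma) with Oryctolagus cuniculus as the target (on this read-out higher numbers stand for weaker inhibition and lower numbers for stronger inhibition), compound 1 `COC(=O)NC(CC(=O)N1CCC(Cn2c(C)nc3cnccc32)CC1)c1ccccc1` gives 12 nM, compound 2 `Cc1nc2cnccc2n1CC1CCN(C(=O)CC(C)c2ccccc2)CC1` gives 12 nM and compound 3 `CCCC(CC(=O)N1CCC(Cn2c(C)nc3cnccc32)CC1)c1ccccc1` gives 11 nM, so compound 3 stands level with the other two within the scatter. Compound 4 `Cc1nc2cnccc2n1CC1CCN(C(=O)CC(C)(C)c2ccccc2)CC1` has 1-methyl-1-phenylethyl in place of the 1-phenylbutyl of compound 3 on a saturated chain carbon bound to a carbonyl carbon: 1-methyl-1-phenylethyl in place of 1-phenylbutyl on a saturated chain carbon bound to a carbonyl carbon. Three measured side-chain changes bear on this: no change at the digits printed from compound 1 to compound 2 (within the scatter), a 1.1-fold lower number from compound 1 to compound 3 (0.04 log units; within the scatter) and a 1.1-fold lower number from compound 2 to compound 3 (0.04 log units; within the scatter). All stay within the scatter, so no step beyond it is expected in this assay, in either direction. Within the data shown here, no measured compound carries the entering group, so the range stays wide. The expected step is a 1.1-fold higher number from compound 3 to compound 4 (0.04 log units; within the scatter). Compound 4 is expected at 12 nM, within an estimated range of 5 nM to 30 nM.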

Compound 4, half-maximal inhibitory concentration: 6.7 nM
Beside the measured number, compound 4's estimate is 1.8-fold (0.25 log units) above it, within the range that was stated.
By their numbers in this assay, from the lowest: compounds 4, 3, 1 and 2 (each within the scatter of the next).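

In this assay, 1-methyl-1-phenylethyl in place of 1-phenylbutyl gives a 1.6-fold lower number from compound 3 to compound 4 (0.22 log units; within the scatter), and adding a methyl in place of hydrogen gives a 1.8-fold lower number from compound 2 to compound 4 (0.25 log units; within the scatter). The number therefore holds level even when the carbon carrying the phenyl ring also bears two methyl groups, whereas each earlier compound had only one substituent there besides the phenyl ring. Nothing measured here explains this tolerance.

From the compounds shown here alone, whether an amine or a carboxylic acid on this carbon would also keep the number level remains open.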